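A few compounds are considered here, and "the series" means these few. Any claim that something is new, unique, unknown or untested is made for them only; others in the source may bear on it.

Compound 2 `COc1cc(OCc2ccc(Cl)cc2)ccc1CNCc1ccncc1` and compound 1 `COc1cc(OCc2cnc(Cl)c(Cl)c2)ccc1CNCc1ccncc1` share one core. In a functional assay on HeLa cells (Homo sapiens) for inhibition, with a stated time of 72 h (on this read-out higher numbers stand for an effect only at larger amounts of compound and lower numbers for an effect already at smaller amounts), compound 2 gives 440 nM, and compound 1 gives 400 nM. The change between them is 5,6-dichloropyridin-3-yl in place of 4-chlorophenyl on a saturated chain carbon bound to an oxygen on an aromatic ring, and the step it made is a 1.1-fold lower number from compound 2 to compound 1 (0.04 log units; within the scatter). Compound 3 `COc1cc(CNCc2ccncc2)ccc1OCc1ccc(Cl)cc1` is built from the same atoms as compound 2, joined differently; the difference between the two cores is not broken down here. In this assay compound 3 gives 890 nM, the highest of the three numbers. Compound 4 `COc1cc(CNCc2ccncc2)ccc1OCc1cnc(Cl)c(Cl)c1` has not yet been measured. It differs from compound 3 by 5,6-dichloropyridin-3-yl in place of 4-chlorophenyl on a saturated chain carbon bound to an oxygen on an aromatic ring, the same change seen from compound 2 to compound 1. The step is expected to be a 1.1-fold lower number from compound 3 to compound 4 (0.05 log units; within the scatter), because a 1.1-fold lower number from compound 2 to compound 1 (0.04 log units; within the scatter) stayed within the scatter. Compound 4 is therefore estimated at 800 nM, expected between 400 nM and 1600 nM.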

Compound 4, half-maximal effective concentration: 220 nM
The estimate for compound 4 lay 3.6-fold (0.56 log units) above the measured number; the whole stated range lies above it.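

The swap of 4-chlorophenyl for 5,6-dichloropyridin-3-yl gives a clear gain on the core of compound 3, with a 4.0-fold lower number from compound 3 to compound 4 (0.61 log units; beyond the scatter), so its size did not carry over from one core to the other in this assay: the same change on two cores in this assay, a 1.1-fold lower number (0.04 log units; within the scatter) from compound 2 to compound 1 and a 4.0-fold lower number (0.61 log units; beyond the scatter) from compound 3 to compound 4, 3.7-fold (0.57 log units) apart, beyond the scatter of two such steps. The result shows that the effect of this change depends on the core that carries it, at least for these two cores. It does not show why the two cores differ, and two pairs cannot predict the step on a further core.

Every compound shown keeps the same methoxy group and the same secondary amine. As far as these compounds go, it stays open how this swap behaves on a core with an ethoxy group or an amide in those places.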